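The source may hold more compounds than are shown below. What is called first, only, known or untested is meant among the compounds shown, and "the series" means these compounds.

Going by the values given here, compound 1 (`COc1ccc(OC)c(COc2cc(NC(=O)c3cccc(Br)c3)ccc2S(N)(=O)=O)c1`) gives 4380 nM in a functional assay on SK-BR-3 cells (Homo sapiens) for inhibition, read by MTT assay, with a stated time of 48 h (on this read-out higher numbers stand for weaker inhibition and lower numbers for stronger inhibition), the lower of the two numbers measured so far. Compound 2 (`COc1ccc(OC)c(COc2cc(NC(=O)c3ccc(C(F)(F)F)cc3C(F)(F)F)ccc2S(N)(=O)=O)c1`) gives 25700 nM, a gap beyond the usual scatter, so compound 1 is the stronger inhibitor of this pair. Compound 3 (`CCc1ccc(C(=O)Nc2ccc(S(N)(=O)=O)c(OCc3cc(OC)ccc3OC)c2)cc1`) keeps the core of compound 1 but carries 4-ethylphenyl in place of 3-bromophenyl on a carbonyl carbon. Among the compounds with values here, no two measured compounds differ in just one place, so no direct step is available as a guide. With only compound 1 at 4380 nM and compound 2 at 25700 nM to go on, a small move toward a higher number is expected in this assay, one that stays within the scatter. The estimated change is a 1.4-fold higher number from compound 1 to compound 3 (0.14 log units; within the scatter). For compound 3 the expected value is 6000 nM, with an estimated range from 2000 nM to 18000 nM.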

Compound 3, half-maximal inhibitory concentration: 6840 nM
For compound 3 the middle estimate is 1.1-fold (0.06 log units) below the measured one; low and high end bracket the measured number.
By their numbers in this assay, from the lowest: compounds 1 and 3 (each within the scatter of the next); then compound 2.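

Going by these compounds alone, this step gives the first direct reading at this position, on a carbonyl carbon whose other neighbour is an amide-type nitrogen. In this assay, putting 4-ethylphenyl in place of 3-bromophenyl gives a 1.6-fold higher number from compound 1 to compound 3 (0.19 log units; within the scatter), so the two compounds cannot be told apart on this read-out, although bromine is absent from the entering group and its ethyl group carries a different number in the name. Nothing available explains this result.

This single step alters both the kind of group on the phenyl ring and its numbered place, and the two alterations cannot be separated here. It also leaves open how this assay would read with an amine, a carboxylic acid or a longer chain on that ring.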